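Octyl and hexyl thiophosphate dithiocarbamates tested on breast cancer cells

The source may hold more compounds than are shown below. What is called first, only, known or untested is meant among the compounds shown, and "the series" means these compounds.

Measured compounds:
compound 1, `CCCCCCCCOP(=O)(O)OCCSC(=S)N1CCCCC1`, 26000 nM
compound 2, `CCCCCCCCOP(=O)(O)OCCSC(=S)N1CCN(C)CC1`, 46000 nM
compound 3, `CCCCCCOP(=O)(O)OCCSC(=S)N1CCCCC1`, 62000 nM

In a functional assay on MCF7 cells (Homo sapiens) for inhibition, read by MTT assay, with stated times of 18 h and 4 h (a lower number here means a stronger inhibitor, a higher number a weaker inhibitor), compound 1 gives 26000 nM, compound 2 gives 46000 nM, and compound 3 gives 62000 nM. The step of a 2.4-fold higher number from compound 1 to compound 3 (0.38 log units; beyond the scatter) is the one difference here that lies beyond the scatter; it corresponds to hydrogen in place of ethyl on a saturated chain carbon, six bonds along the chain from an oxygen on an unsaturated carbon, which is also how the core of compound 3 differs from the core of compound 1.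

Compound 4, `CCCCCCOP(=O)(O)OCCSC(=S)N1CCN(C)CC1`, has not yet been measured. It differs from compound 3 by 4-methylpiperazin-1-yl in place of piperidin-1-yl on a thiocarbonyl carbon. The same change was made from compound 1 to compound 2, (4-methylpiperazin-1-yl in place of piperidin-1-yl on a thiocarbonyl carbon), and there it gave a 1.8-fold higher number from compound 1 to compound 2 (0.25 log units; within the scatter). Since the two changes occur at the same place, compound 4 is expected to show a similar step, a 1.6-fold higher number from compound 3 to compound 4 (0.21 log units; within the scatter), resting on the step of a 1.8-fold higher number from compound 1 to compound 2 (0.25 log units; within the scatter). Compound 4 is therefore estimated at 100000 nM, with a range from 40000 nM to 250000 nM.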

Compound 4, half-maximal inhibitory concentration: 58000 nM
The estimate for compound 4 lay 1.7-fold (0.24 log units) above the measured number; the measured number falls inside the stated range.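

In this assay, 4-methylpiperazin-1-yl in place of piperidin-1-yl on a thiocarbonyl carbon gives a 1.1-fold lower number from compound 3 to compound 4 (0.03 log units; within the scatter), and this does not differ from the earlier step: the same change on two cores in this assay, a 1.8-fold higher number (0.25 log units; within the scatter) from compound 1 to compound 2 and a 1.1-fold lower number (0.03 log units; within the scatter) from compound 3 to compound 4, 1.9-fold (0.28 log units) apart, within the scatter of two such steps. Shortening the chain with 4-methylpiperazin-1-yl in place gives a 1.3-fold higher number from compound 2 to compound 4 (0.10 log units; within the scatter), which also does not separate from its earlier counterpart: the same change on two cores in this assay, a 2.4-fold higher number (0.38 log units; beyond the scatter) from compound 1 to compound 3 and a 1.3-fold higher number (0.10 log units; within the scatter) from compound 2 to compound 4, 1.9-fold (0.28 log units) apart, within the scatter of two such steps. Among these compounds, both changes therefore carry over between these cores as far as the data can tell, but this does not fix the size of either step, since three of the four steps lie within the scatter and only two chains and two rings are compared.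

As far as these compounds go, it remains open how a chain longer than octyl would read in this assay. The same holds for a morpholine ring or an open-chain diethylamino group on the thiocarbonyl carbon.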